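This account rests on a few compounds, and the source may have more. Where it says the series, first, only, none or still open, it means among the compounds named here.

Values so far in a functional assay on SK-BR-3 cells (Homo sapiens) for antiproliferative activity, with a stated time of 48 h (on this read-out lower numbers stand for an effect already at smaller amounts and higher numbers for an effect only at larger amounts of compound), for the series:
compound 1 `Nc1ccc(NC(=O)CCCCCCC(=O)NO)cc1` gives 8500 nM
compound 2 `O=C(CCCCCCC(=O)Nc1cccc(F)c1)NO` gives 1900 nM
compound 3 `O=C(CCCCCCC(=O)Nc1ccc(Cl)cc1)NO` gives 2300 nM

Compound 2 and compound 3 lie within the scatter of each other, and both numbers sit beyond the scatter under that of compound 1. Next in line is compound 4 `O=C(CCCCCCC(=O)Nc1cccc(Cl)c1)NO` still unmeasured. Going from compound 2 to compound 4 means chloro in place of fluoro on an aromatic carbon with chloro in place of fluoro on an aromatic carbon, meta to a large group. Going by the values given here, the one measured step is a 3.7-fold lower number from compound 1 to compound 3 (0.57 log units; beyond the scatter) and it is modest, but it replaces amino rather than fluoro, so it bears only indirectly. More useful is that compound 3 with chloro gives 2300 nM on the same level as fluoro compound 2, though the two also differ in where the halogen sits. No step beyond the scatter is therefore expected in this assay for this exchange. The estimated step is a 1.1-fold higher number from compound 2 to compound 4 (0.02 log units; within the scatter) and it stays within the scatter. For compound 4 the estimated value is 2000 nM with an expected range from 950 nM to 4000 nM on this read-out.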

Compound 4, half-maximal effective concentration: 2000 nM
Beside the measured number, compound 4's estimate shows no gap at the digits printed; low and high end bracket the measured number.
By their numbers in this assay, from the lowest: compounds 2, 4 and 3 (each within the scatter of the next); then compound 1.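

Exchanging fluoro for chloro on an aromatic carbon, meta to a large group, gives a 1.1-fold higher number from compound 2 to compound 4 (0.02 log units; within the scatter) in this assay and so can now be read at a single position. The earlier compounds shown here offered only a fluoro compound and a chloro compound with the halogen at different places, whereas this pair differs in the halogen alone, and at this position the read-out does not separate the two halogens. Nothing measured here offers an explanation for this result.

Still open, from the compounds shown here alone, is whether a group other than a halogen at this position, such as methoxy, trifluoromethyl or a carboxylic acid, would stay on the level of the two halogens. Also open, going by these compounds, is whether a longer chain between the amide carbonyl and the hydroxamic acid would shift the numbers of these halogen compounds.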